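Swapping 4-fluorophenyl for 3-methoxyphenyl on the shared core

The source may hold more compounds than are shown below. What is called first, only, known or untested is meant among the compounds shown, and "the series" means these compounds.

In a functional assay on MCF7 cells (Homo sapiens) for inhibition, read by sulforhodamine B assay, with a stated time of 48 h (on this read-out higher numbers stand for weaker inhibition and lower numbers for stronger inhibition), compound 2 (`CSc1nn(-c2ccccc2)c2ncnc(N/N=C/c3ccc(F)cc3)c12`) gives 7.5 nM and compound 1 (`CSc1nn(-c2ccccc2)c2ncnc(N/N=C/c3ccc(Cl)cc3)c12`) gives 12.1 nM, so the two stand level within the scatter. Among the compounds with values here, the only measured step, a 1.6-fold lower number from compound 1 to compound 2 (0.21 log units; within the scatter), is fluoro in place of chloro on an aromatic carbon, and it lies within the scatter.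

Compound 3 (`COc1cccc(/C=N/Nc2ncnc3c2c(SC)nn3-c2ccccc2)c1`) has 3-methoxyphenyl in place of 4-fluorophenyl on a carbon with a double bond to nitrogen. Within the data shown here, no measured compound carries a methoxy group, so the evidence is indirect and thin. Among the measured compounds shown here, the halogen exchange on this same aromatic ring is the one step that bears on the change, and it stayed small. No step beyond the scatter is therefore expected in this assay. The expected step is a 1.5-fold higher number from compound 2 to compound 3 (0.17 log units; within the scatter), with wide uncertainty. For compound 3 the estimated value is 11 nM, with an expected range of 3 nM to 40 nM.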

Compound 3, half-maximal inhibitory concentration: 11.1 nM
Estimate against measurement, compound 3: 1.0-fold (0.00 log units) below; the measured number falls inside the stated range.
By their numbers in this assay, from the lowest: compounds 2, 3 and 1 (each within the scatter of the next).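

In this assay, the change at the carbon with a double bond to nitrogen now goes beyond a halogen exchange on the same ring: 3-methoxyphenyl in place of 4-fluorophenyl gives a 1.5-fold higher number from compound 2 to compound 3 (0.17 log units; within the scatter), and 3-methoxyphenyl in place of 4-chlorophenyl gives a 1.1-fold lower number from compound 1 to compound 3 (0.04 log units; within the scatter). Both steps lie within the scatter, so compounds 1, 2 and 3 stand level, and the hydrogen-bond acceptor counted in 3-methoxyphenyl, absent from 4-fluorophenyl, goes with no step beyond the scatter at this place. Nothing on hand explains why these three aryl groups stand level.

Since group and ring position change together in this step, 4-methoxyphenyl would be needed to separate the two. Going by these compounds, whether any group here gives a step beyond the scatter stays open, for instance an aminophenyl or carboxyphenyl ring, or a longer alkyl chain in place of the ring.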